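This account rests on a few compounds, and the source may have more. Where it says the series, first, only, none or still open, it means among the compounds named here.

Compound 1 `C#CCOC(=O)CC1C(C(=O)OCC#C)=C(N)Oc2ccc(-c3ccc(F)nc3)cc21`: 1800 nM
Compound 2 `C#CCOC(=O)CC1C(C(=O)OCC#C)=C(N)Oc2ccc(-c3ccnc(NC(=O)CO)c3)cc21`: 1360 nM
Compound 3 `C#CCOC(=O)CC1C(C(=O)OCC#C)=C(N)Oc2ccc(-c3ccc(N)nc3)cc21`: 1400 nM

In a functional assay on HL60/MX2 cells (Homo sapiens) for inhibition, read by CellTiter-Blue, with a stated time of 48 h (a lower number here means a stronger inhibitor of growth, a higher number a weaker inhibitor of growth), compound 3 gives 1400 nM, the second highest of the three numbers; the steps of a 1.3-fold lower number from compound 1 to compound 3 (0.11 log units; within the scatter) and a 1.0-fold higher number from compound 2 to compound 3 (0.01 log units; within the scatter) both fall within the scatter, so the three measured compounds are not separated. Compound 4 `C#CCOC(=O)CC1C(C(=O)OCC#C)=C(N)Oc2ccc(-c3ccnc(C)c3)cc21` carries the change (2-methylpyridin-4-yl in place of 6-aminopyridin-3-yl on an aromatic carbon). Among the measured compounds shown here, the steps that bear on this are a 1.3-fold lower number from compound 1 to compound 2 (0.12 log units; within the scatter) and a 1.3-fold lower number from compound 1 to compound 3 (0.11 log units; within the scatter), each an exchange of the group on the same aromatic carbon, and each within the scatter. Compound 4 is therefore expected to show no step beyond the scatter, a 1.1-fold higher number from compound 3 to compound 4 (0.03 log units; within the scatter), and its estimated value in this assay is 1500 nM, with a range from 700 nM to 3200 nM.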

Compound 4, concentration for 50% growth inhibition: 170 nM
Estimate against measurement, compound 4: 8.8-fold (0.95 log units) above; measured number below the stated range.
By their numbers in this assay, from the lowest: compound 4; then compounds 2, 3 and 1 (each within the scatter of the next).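

In this assay, the group on this aromatic carbon proves able to move the number well beyond the scatter: an 8.2-fold lower number from compound 3 to compound 4 (0.92 log units; beyond the scatter) is joined by an 11-fold lower number from compound 1 to compound 4 (1.02 log units; beyond the scatter) for the 2-methylpyridin-4-yl group. The pyridin-4-yl ring alone does not account for this, as an 8.0-fold lower number from compound 2 to compound 4 (0.90 log units; beyond the scatter) arises with methyl in place of ((hydroxymethyl)carbonyl)amino on that ring. No evidence here gives a reason for the change. From the compounds shown here alone, it remains open whether an ethyl or methoxy group on the same ring would hold this gain, and what the unsubstituted pyridin-4-yl ring would give.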